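This account rests on a few compounds, and the source may have more. Where it says the series, first, only, none or still open, it means among the compounds named here.

Compound 1 `CN1CCC(c2c[nH]c3ccc(NC(=O)c4cccc(F)c4)nc23)CC1` — in an assay for binding affinity to 5-hydroxytryptamine receptor 1F (Homo sapiens), read by radioligand binding (a higher number here means a weaker inhibitor, a lower number a stronger inhibitor), compound 1 gives 11 nM.
Compound 2 `Cc1cccc(C(=O)Nc2ccc3[nH]cc(C4CCN(C)CC4)c3n2)c1` — in this assay compound 2 gives 5.8 nM.

For the measured compounds named here, compound 2 gives the lowest of the two numbers, but its only neighbour is compound 1, and the step of a 1.9-fold lower number from compound 1 to compound 2 (0.28 log units; within the scatter) is within the scatter, so the two cannot be told apart on these data.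

Compound 3 `CCCC(=O)Nc1ccc2[nH]cc(C3CCN(C)CC3)c2n1` differs from compound 2 by propyl in place of 3-methylphenyl on a carbonyl carbon; the change sits on a carbonyl carbon whose other neighbour is the amide-type nitrogen. Going by the values given here, the one measured step, from compound 1 to compound 2, swaps a single group on the aromatic ring that is now removed altogether, and it was within the scatter. Among the compounds with values here, no measured step removes the ring itself or puts a chain in its place, so nothing here speaks directly to the size of this change.

With the amide-side ring gone and a short chain in its place, a somewhat higher number is expected for compound 3, an estimated step of a 5.2-fold higher number from compound 2 to compound 3 (0.71 log units; beyond the scatter). The expected value for compound 3 is 30 nM, with a range from 8 nM to 120 nM.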

Compound 3, inhibition constant: 6.9 nM
Compound 3: the middle estimate sits 4.3-fold (0.64 log units) above what was measured, outside the stated range (below it).
By their numbers in this assay, from the lowest: compounds 2, 3 and 1 (each within the scatter of the next).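

The ring on the carbonyl carbon turns out not to be required for binding in this assay. Replacing 3-methylphenyl, a group of 7 heavy atoms with an aromatic ring, by propyl, a ringless group of 3 heavy atoms, gives a 1.2-fold higher number from compound 2 to compound 3 (0.08 log units; within the scatter) and so cannot be told apart from no change, and replacing 3-fluorophenyl by propyl gives a 1.6-fold lower number from compound 1 to compound 3 (0.20 log units; within the scatter) and reads the same way. For the compounds shown here, the earlier compounds showed only that one small group on this ring could stand in for another, whereas these steps show that the whole ring can give way to a short chain, although no measured finding here explains this tolerance.

All three compounds lie within the scatter of one another, so the compounds shown do not reveal any group at this place that moves the number by a readable amount. On these data alone, it remains open how far that tolerance extends, for instance to a single methyl, a longer chain such as octyl, or a chain ending in an amine or a carboxylic acid.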